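The source may report more compounds than this note shows. Statements on the series, on what has been measured and on what is new or still open speak of the compounds shown alone.

Measured compounds:
compound 1 `O=C1c2c(O)cc(O)cc2O[C@@H](c2c(O)cccc2O)[C@@H]1O`: 100000 nM
compound 2 `O=C1c2c(O)cc(O)cc2O[C@@H](c2cccc(O)c2O)[C@@H]1O`: 13500 nM
compound 3 `O=C1c2c(O)cc(O)cc2O[C@H](c2cccc(O)c2)[C@H]1O`: a limit of the assay, > 100000 nM

In a physicochemical assay, read by spectrophotometry, with a stated time of 30 min (a lower number here means that less compound is needed, a higher number that more compound is needed for the effect), compound 1 gives 100000 nM, the higher of the two numbers that were read; compound 2 gives 13500 nM, and the gap between the two lies beyond the scatter. For compound 3 the assay reports only a limit, > 100000 nM (the limit of > 100000 nM in this assay, at which 1 of the 3 values shown sits). Among the compounds with values here, compound 4 `O=C1c2c(O)cc(O)cc2O[C@H](c2c(O)cccc2O)[C@H]1O` has not yet been measured. the two compounds have the same atoms and bonds and differ only in configuration as drawn: 2 of 2 stereo elements differ (all stereocentres are inverted: mirror images); a stereocentre at a saturated ring carbon is drawn S in compound 1 and R in compound 4; a stereocentre at a saturated ring carbon is drawn S in compound 1 and R in compound 4 No measured pair differs in this way, so no step of this kind can be read from the data. The step expected in this assay from compound 1 to compound 4, no change at the digits printed from compound 1 to compound 4 (within the scatter), is none beyond the scatter. Compound 4 is therefore estimated at 100000 nM, within 50000 nM to 200000 nM.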

Compound 4, half-maximal effective concentration: > 100000 nM
Compound 4 was reported as a limit; the forecaster's own chance of this, stated with the estimate: 25%; the middle value lies on the limit itself.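

In this assay, compound 4 gives > 100000 nM, which is a limit of the assay and not a number. Inverting both stereocentres gives a number no lower from compound 1 to compound 4 (the limit leaves the size open), the first step here that concerns configuration alone: the fact that compounds 1 and 4 differ only in the configuration as drawn The size of that step cannot be read, because the value of compound 4 sits at the assay's limit: the limit of > 100000 nM in this assay, at which 2 of the 4 values shown sit.

Still open, going by these compounds, is whether the drawn configuration matters to the same degree with the other hydroxyl patterns. Also open, on these data alone, is how an amine or a carboxylic acid on the shared core would behave in either configuration.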